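Trimming the Ester of Compound 3 to Cyclopropyl

The source may report more compounds than this note shows. Statements on the series, on what has been measured and on what is new or still open speak of the compounds shown alone.

Three esters of a shared core have been tested in a functional assay on A549 cells (Homo sapiens) for cytotoxicity, read by MTT assay, with a stated time of 48 h (a lower number here means a stronger inhibitor, a higher number a weaker inhibitor), so far. Here compound 1 (`C=C1C(=O)O[C@H]2CC3=C[C@H](C/C(C)=C/[C@@H](OC(=O)/C=C/c4ccc(N(C)C)cc4)[C@H]12)OC3=O`) reaches only a limit (> 10000 nM). Compound 2 (`C=C1C(=O)O[C@H]2CC3=C[C@H](C/C(C)=C/[C@@H](OC(=O)CCCCC)[C@H]12)OC3=O`) likewise reaches only a limit (> 10000 nM). Going by the values given here, compound 3 (`C=C1C(=O)O[C@H]2CC3=C[C@H](C/C(C)=C/[C@@H](OC(=O)C45CCC(C)(C(=O)O4)C5(C)C)[C@H]12)OC3=O`) gives the only actual number (3400 nM). Most of the series therefore sits at one limit (the limit of > 10000 nM in this assay, at which 2 of the 3 values shown sit).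

Compound 4 (`C=C1C(=O)O[C@H]2CC3=C[C@H](C/C(C)=C/[C@@H](OC(=O)C4CC4)[C@H]12)OC3=O`) differs from compound 3 at one place, on a carbonyl carbon, where cyclopropyl enters (a group of 3 heavy atoms (3 carbon; one three-membered non-aromatic ring of carbon only) in place of a group of 11 heavy atoms (9 carbon, 2 oxygen; one five-membered non-aromatic ring of carbon only, one five-membered non-aromatic ring with 1 hetero atom), on a carbonyl carbon). The steps of an at least 2.9-fold lower number from compound 2 to compound 3 (0.46 log units; beyond the scatter) and an at least 2.9-fold lower number from compound 1 to compound 3 (0.46 log units; beyond the scatter) both lie beyond the scatter and bear on this change, while the step that the two limits leave unreadable from compound 1 to compound 2 adds nothing readable.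

Because an at least 2.9-fold lower number from compound 2 to compound 3 (0.46 log units; beyond the scatter) came with the group that compound 4 gives up, a modest move to a higher number in this assay is expected, and a limit is quite possible. The expected step is modest (a 2.6-fold higher number from compound 3 to compound 4 (0.42 log units; beyond the scatter)). For compound 4 the estimated value is about (9000 nM), with an expected range (3500 nM to 25000 nM).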

Compound 4, half-maximal inhibitory concentration: 3200 nM
The estimate for compound 4 lay 2.8-fold (0.45 log units) above the measured number; measured number outside the range, below it.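

In this assay, the group of 11 heavy atoms in compound 3 turns out not to be required on this carbonyl carbon: cyclopropyl in its place gives a 1.1-fold lower number from compound 3 to compound 4 (0.03 log units; within the scatter). Cyclopropyl also stands apart from the other two esters, with an at least 3.1-fold lower number from compound 2 to compound 4 (0.49 log units; beyond the scatter) and an at least 3.1-fold lower number from compound 1 to compound 4 (0.49 log units; beyond the scatter), so among these four compounds, the two that give a number both carry a non-aromatic ring at this place, while pentyl has no ring and the 2-(4-(dimethylamino)phenyl)ethenyl group has an aromatic one. Both of these steps start from a limit rather than a number, and the step between compound 1 and compound 2 cannot be read: the limit of > 10000 nM in this assay, at which 2 of the 4 values shown sit.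

The compounds shown leave open whether the ring itself matters, or whether an open isopropyl group would serve equally well on this carbonyl carbon. They also leave open whether cyclobutyl or a cyclopropyl bearing an amine would shift the number in either direction.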